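The compounds below may be only part of what the source reports. "The series", "measured", "known", "first", "only" and "open" are said of these compounds alone.

Measured so far:
- compound 1 `COc1cc(N)c(Cl)cc1C(=O)NC1CCN(CCCCCO)CC1` gives 63.1 nM in an assay on HEK293 cells for displacement of a labelled ligand from 5-hydroxytryptamine receptor 4 (Homo sapiens), read by scintillation counting; a lower number here means a stronger inhibitor, a higher number a weaker inhibitor
- compound 2 `COc1cc(N)c(Cl)cc1C(=O)NC1CCN(CCN2C(=O)c3ccccc3C2=O)CC1` gives 7940 nM in this assay
- compound 3 `COc1cc(N)c(Cl)cc1C(=O)NC1CCN(CCN2CCCCC2)CC1` gives 251 nM in this assay

Compound 1 holds the lowest number of the three in this assay; its nearest neighbour is compound 3, and compound 2 stands far above both. The unmeasured compound 4 `COc1cc(N)c(Cl)cc1C(=O)NC1CCN(CCCCCCCCN2CCCCC2)CC1` differs from compound 1 by 3-(piperidin-1-yl)propyl in place of hydroxy on a saturated chain carbon, five bonds along the chain from an amine nitrogen in a ring, so the chain of compound 1 is kept and lengthened and its hydroxy end is replaced by a piperidine.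

For the measured compounds named here, one measured step bears on this. Replacing the hydroxypropyl-bearing end of the chain with a piperidine close to the ring amine gave a 4.0-fold higher number from compound 1 to compound 3 (0.60 log units; beyond the scatter), a modest rise. Going by the values given here, compound 4 places its piperidine much further out along a longer chain, and no measured pair tests that distance directly. The values of compound 1 and compound 2 show that a bulky ring close to the ring amine can cost a great deal, but compound 4 carries no such group. Compound 4 is therefore expected to show a modest rise in this assay, a 2.5-fold higher number from compound 1 to compound 4 (0.40 log units; beyond the scatter), with the estimate for compound 4 at 160 nM and a range from 40 nM to 630 nM.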

Compound 4, inhibition constant: 3.16 nM
Estimate against measurement, compound 4: 51-fold (1.70 log units) above; the measured number lies below the stated range.
By their numbers in this assay, from the lowest: compound 4; then compound 1; then compound 3; then compound 2.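

In this assay, 3-(piperidin-1-yl)propyl in place of hydroxy, on a saturated chain carbon five bonds along the chain from an amine nitrogen in a ring, gave a 20-fold lower number from compound 1 to compound 4 (1.30 log units; beyond the scatter), a change in the opposite direction to the earlier 4.0-fold higher number from compound 1 to compound 3 (0.60 log units; beyond the scatter). A terminal piperidine therefore does not carry a cost in itself: compound 3 stands at 251 nM and compound 4 at 3.16 nM, so the printed values lie far apart for two compounds that both end in this ring on chains of different length. No measurement shown here accounts for the lower number.

On these data alone, whether it belongs to the longer chain itself or to the piperidine at its end remains open. Also open, as far as these compounds go, is how a morpholine or a dimethylamino group at the end of that chain would compare, or a still longer chain.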